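Moving the fluorine on the benzamide ring of compound 1

This account rests on a few compounds, and the source may have more. Where it says the series, first, only, none or still open, it means among the compounds named here.

Measured so far:
- compound 1 `COc1cc2ncnc(Nc3ccc(NC(=O)c4cccc(F)c4)cc3)c2cc1OC`: 8200 nM
- compound 2 `COc1cc2ncnc(Nc3ccc(NC(=O)c4ccc(Cl)cc4)cc3)c2cc1OC`: 28000 nM
- compound 3 `COc1cc2ncnc(Nc3ccc(NC(=O)c4ccc(I)cc4)cc3)c2cc1OC`: 40000 nM

These values come from a functional assay on HepG2 cells (Homo sapiens) for inhibition, read by MTT assay; a higher number here means a weaker inhibitor, a lower number a stronger inhibitor. Compound 1 gives the lowest number of the three, and both other compounds lie beyond the scatter above it. Compound 4 `COc1cc2ncnc(Nc3ccc(NC(=O)c4c(F)cccc4F)cc3)c2cc1OC` differs from compound 1 in one place: 2,6-difluorophenyl in place of 3-fluorophenyl on a carbonyl carbon. The steps that touch the same group are a 3.4-fold higher number from compound 1 to compound 2 (0.53 log units; beyond the scatter) and a 4.9-fold higher number from compound 1 to compound 3 (0.69 log units; beyond the scatter); each swapped the 3-fluorophenyl for something else and weakened inhibition. Neither tested 2,6-difluorophenyl, so the direction is uncertain, and a small rise is expected, giving a 1.6-fold higher number from compound 1 to compound 4 (0.20 log units; within the scatter). The value of compound 4 in this assay is estimated at 13000 nM, within 4000 nM to 45000 nM.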

Compound 4, half-maximal inhibitory concentration: 17000 nM
Compound 4: middle estimate off by 1.3-fold (0.12 log units), on the low side; low and high end bracket the measured number.
By their numbers in this assay, from the lowest: compound 1; then compounds 4, 2 and 3 (each within the scatter of the next, the first and the last beyond it).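

The step of a 2.1-fold higher number from compound 1 to compound 4 (0.32 log units; beyond the scatter) in this assay shows that 2,6-difluorophenyl, with two fluorines on the ring, also fails to match the 3-fluorophenyl on this carbonyl carbon. The other two steps read a 2.4-fold lower number from compound 3 to compound 4 (0.37 log units; beyond the scatter) and a 1.6-fold lower number from compound 2 to compound 4 (0.22 log units; within the scatter) so the new group improves on 4-iodophenyl but cannot be told apart from 4-chlorophenyl. Nothing available gives a reason for these differences.

The compounds shown all carry a halogenated phenyl here, so it remains open how an amine or a carboxylic acid on this ring would fare. As far as these compounds go, whether any group at this place can improve on compound 1 also remains open.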